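The compounds below may be only part of what the source reports. "The series", "measured", "known", "first", "only" and "open" are said of these compounds alone.

Measured compounds:

Compound 1 `COc1ccc(-c2cc(/C=C/C(=O)c3ccc(N)cc3)[nH]n2)cc1` gives -86% in a functional assay on OVCAR-5 cells (Homo sapiens) for cytotoxicity, read by sulforhodamine B assay, with a stated time of 48 h, tested at 100 uM; on this read-out lower numbers stand for a stronger effect and higher numbers for a weaker effect at the one concentration tested.
Compound 2 `COc1ccc(C(=O)/C=C/c2cc(-c3cc(OC)c(OC)c(OC)c3)n[nH]2)cc1OC` gives -71% in this assay.
Compound 3 `COc1ccc(-c2cc(/C=C/C(=O)c3ccc(N)cc3)[nH]n2)cc1OC` gives -81% in this assay.

All three compounds carry the same kind of side chain, a carbonyl joined through a double bond to a pyrazole ring, but the cores of compound 1 and compound 2 are built differently, and the difference between the two cores is not broken down here. Compound 3 arises from compound 1 by one change, (methoxy in place of hydrogen on an aromatic carbon), and that change moved the read-out by a number 5 percentage points higher from compound 1 to compound 3 (within the scatter). Compound 2 shows the highest of the three numbers, but its distance from compound 3 lies within the scatter, while its distance from compound 1 lies beyond it.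

Compound 4 `COc1cc(C(=O)/C=C/c2cc(-c3cc(OC)c(OC)c(OC)c3)n[nH]2)cc(OC)c1OC` has not yet been measured in this assay. It arises from compound 2 by methoxy in place of hydrogen on an aromatic carbon. Going by the values given here, this is the same kind of change as the one from compound 1 to compound 3, though the surroundings are not identical: in compound 4 the new group sits not only ortho to a methoxy group and meta to a large group, but also meta to a further methoxy group.

Because the earlier change gave a number 5 percentage points higher from compound 1 to compound 3 (within the scatter), the step from compound 2 to compound 4 is expected to be of similar small size, a number 5 percentage points higher from compound 2 to compound 4 (within the scatter). Compound 4 is therefore expected to give about -66%, most likely between -85% and -45%.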

Compound 4, a percentage reported as activity, at one concentration (the size of the read-out at that concentration, not a potency): -72%
Compound 4: middle estimate off by 6 percentage points, on the high side, within the range that was stated.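

Putting methoxy in place of hydrogen on an aromatic carbon gives, in this assay, a number 1 percentage points lower from compound 2 to compound 4 (within the scatter). Set beside the earlier case, the same change on the two cores gives steps that cannot be told apart: the same change on two cores in this assay, a number 5 percentage points higher (within the scatter) from compound 1 to compound 3 and a number 1 percentage points lower (within the scatter) from compound 2 to compound 4, 6 percentage points apart, within the scatter of two such steps. For these two pairs of compounds, then, the step carries over from one core to the other and stays small on both, but this does not show that methoxy would behave the same way on any other core in the series or at any other place on the ring, and a read-out at one concentration says nothing about potency.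

Every step shown swaps hydrogen for methoxy, which leaves open what a different group at the same place, such as an ethoxy group, a chlorine atom or a carboxylic acid, would do to the read-out. Also open, on these data alone, is what would happen at lower concentrations, where a step hidden at this single high concentration might appear, and how much of the gap between the two cores comes from each of the places in which they differ.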